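This account rests on a few compounds, and the source may have more. Where it says the series, first, only, none or still open, it means among the compounds named here.

Measured so far in an assay for inhibition of Indoleamine 2,3-dioxygenase 1 variant C129Y (Homo sapiens), read by spectrophotometry, with a stated time of 30 min, tested at 10 uM; on this read-out higher numbers stand for more inhibition at the one concentration tested (going by the name of the read-out) and lower numbers for less inhibition:
compound 1 `Cc1cc(C(O)Cc2ccccc2)c2cn[nH]c2c1` gives 18%
compound 2 `OC(Cc1ccccc1)c1cc(Br)cc2[nH]ncc12` gives 23%

Compound 2 stands highest of the two numbers, but only by the step of a number 5 percentage points higher from compound 1 to compound 2 (within the scatter), which lies inside the scatter of repeated runs; the two measured compounds therefore do not separate from one another in this assay.

Compound 3 `C#Cc1cc(C(O)Cc2ccccc2)c2cn[nH]c2c1` is the next compound. Relative to compound 2 the change is ethynyl in place of bromo on an aromatic carbon. Among the measured compounds shown here, the single measured step, bromo in place of methyl on an aromatic carbon, read a number 5 percentage points higher from compound 1 to compound 2 (within the scatter) and stayed within the scatter. For the measured compounds named here, no measured step introduces an ethynyl group, so the numbers give no direct guide to this exchange; the one comparison available is flat, and nothing points to a movement in either direction. Against that background the expected step is a number 2 percentage points lower from compound 2 to compound 3 (within the scatter), meaning no move beyond the scatter. Compound 3 is accordingly estimated at 21%, with a range from 5% to 40% in this assay.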

Compound 3, a percentage reported as inhibition, at one concentration (the size of the read-out at that concentration, not a potency): 12%
For compound 3 the middle estimate is 9 percentage points above the measured one; the measured number falls inside the stated range.
By their numbers in this assay, from the lowest: compounds 3, 1 and 2 (each within the scatter of the next, the first and the last beyond it).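

In this assay the position para to a fused ring now shows its first step beyond the scatter: ethynyl in place of bromo gives a number 11 percentage points lower from compound 2 to compound 3 (beyond the scatter) and is a modest step, so this position is not fully indifferent to the group it carries. Ethynyl in place of methyl gives a number 6 percentage points lower from compound 1 to compound 3 (within the scatter) and stays within the scatter, so only compound 2 and compound 3 separate, and the methyl group cannot be told apart from either the bromo or the ethynyl group. No supporting measurement bears on the drop seen on going from bromo to ethynyl, and the step stands as an observation without an explanation.

As far as these compounds go, whether an amine, a carboxylic acid or a longer chain at this position would move the number well beyond the scatter remains open, as does the direction of any such move. Also open, from the compounds shown here alone, is how far these small differences at one concentration reflect potency, and whether the step from bromo to ethynyl would hold with the group of 9 heavy atoms changed.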